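Swapping a Cyclopropyl for Chloromethyl on the Chain

This account rests on a few compounds, and the source may have more. Where it says the series, first, only, none or still open, it means among the compounds named here.

Of the compounds shown here, three sharing one core have been measured in a functional assay on HEK293 cells for antagonist activity at Voltage-dependent L-type calcium channel subunit alpha-1D (Rattus norvegicus), read by FLIPR; a lower number here means a stronger inhibitor, a higher number a weaker inhibitor. Compound 1 `C=CCOC(=O)C1=C(C)NC(C)=C(C(=O)OC)C1c1cccc([N+](=O)[O-])c1` gives 15 nM, compound 2 `C=C(C)CCOC(=O)C1=C(C)NC(C)=C(C(=O)OC)C1c1cccc([N+](=O)[O-])c1` gives 47 nM, and compound 3 `COC(=O)C1=C(C)NC(C)=C(C(=O)OCC2CC2)C1c1cccc([N+](=O)[O-])c1` gives 21 nM. Compound 3 thus stands second highest of the three: its gap to compound 1 lies within the scatter, while the step of a 2.2-fold lower number from compound 2 to compound 3 (0.35 log units; beyond the scatter) lies beyond it.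

Compound 4 `COC(=O)C1=C(C)NC(C)=C(C(=O)OCCCl)C1c1cccc([N+](=O)[O-])c1` differs from compound 3 at one place only: chloromethyl in place of cyclopropyl on a saturated chain carbon bound to an oxygen next to a carbonyl group. Among the measured compounds shown here, the steps that bear on this position are a 1.4-fold higher number from compound 1 to compound 3 (0.15 log units; within the scatter), a change at the same carbon that stayed within the scatter, and a 3.1-fold higher number from compound 1 to compound 2 (0.50 log units; beyond the scatter), where a larger group gave a modestly higher number. Chloromethyl is the smaller of the two groups exchanged here, so no step beyond the scatter is expected in this assay. Compound 4 is therefore estimated at 20 nM, with a range from 8 nM to 50 nM, which corresponds to an expected step of a 1.1-fold lower number from compound 3 to compound 4 (0.02 log units; within the scatter).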

Compound 4, half-maximal inhibitory concentration: 22 nM
Beside the measured number, compound 4's estimate is 1.1-fold (0.04 log units) below it; the range from low to high includes it.
By their numbers in this assay, from the lowest: compounds 1, 3 and 4 (each within the scatter of the next); then compound 2.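

In this assay, replacing the cyclopropyl ring with open-chain chloromethyl leaves the reading flat (a 1.0-fold higher number from compound 3 to compound 4 (0.02 log units; within the scatter)), so at this place the ring is not needed to hold the number. Compound 4 also sits within the scatter of the vinyl-bearing compound 1 (a 1.5-fold higher number from compound 1 to compound 4 (0.17 log units; within the scatter)), whereas only the 2-methylprop-2-en-1-yl group of compound 2 stands apart (a 2.1-fold lower number from compound 2 to compound 4 (0.33 log units; beyond the scatter)), which leaves three different groups with matching readings and one exception. No measurement shown here offers a reason for this match.

On these data alone, whether the flat reading would hold with an amine or a carboxylic acid at this place stays open. Among the compounds shown here, compound 2 is also the only compound with a higher reading, so a longer chain ending in chlorine could show whether the number rises with chain length.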